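The compounds below may be only part of what the source reports. "The series", "measured", "known", "first", "only" and "open" are said of these compounds alone.

Measured so far in a functional assay on PC-3 cells (Homo sapiens) for antiproliferative activity, read by MTT assay, with a stated time of 48 h; on this read-out higher numbers stand for weaker inhibition of growth and lower numbers for stronger inhibition of growth:
Compound 1 `CCCCCN(Cc1ccc(C(=O)NO)cc1)c1ncc(-c2ccc(C)cc2)s1` gives 5060 nM
Compound 2 `CCN(Cc1ccc(C(=O)NO)cc1)c1ncc(-c2ccc(C)cc2)s1` gives 10300 nM

Compound 1 holds the lower of these two numbers, so it inhibits growth more strongly here. Compound 3 `Cc1ccc(-c2cnc(N(CCCCOc3ccccc3)Cc3ccc(C(=O)NO)cc3)s2)cc1` keeps the core of compound 1 and differs only at the end of the chain: phenoxy in place of methyl on a saturated chain carbon, four bonds along the chain from a nitrogen on an aromatic ring. Within the data shown here, one measured step bears on this chain: a 2.0-fold higher number from compound 1 to compound 2 (0.31 log units; beyond the scatter), a modest change, with hydrogen in place of propyl. Among the measured compounds shown here, no measured compound carries phenoxy, so this is weak guidance, and only a small shift toward stronger inhibition is expected, possibly within the scatter. The expected step is a 1.3-fold lower number from compound 1 to compound 3 (0.10 log units; within the scatter). For compound 3 the estimate is 4000 nM, with an expected range of 1500 nM to 10000 nM.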

Compound 3, concentration for 50% growth inhibition: 10300 nM
Compound 3: middle estimate off by 2.6-fold (0.41 log units), on the low side; measured number outside the range, above it.
By their numbers in this assay, from the lowest: compound 1; then compounds 2 and 3 (each within the scatter of the next).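

Phenoxy in place of methyl at the chain end weakens growth inhibition in this assay (a modest step, a 2.0-fold higher number from compound 1 to compound 3 (0.31 log units; beyond the scatter)). Against the short-chain compound, 2-phenoxyethyl in place of hydrogen gives no change at the digits printed from compound 2 to compound 3 (within the scatter), so a longer chain does not by itself bring stronger inhibition at this position, and compound 3 goes against that idea. Nothing measured here explains this result.

Open, on these data alone, is how a plain longer chain, or a chain ending in an amine or a carboxylic acid, would compare. Also open, as far as these compounds go, is whether a chain ending in phenyl, without the ether oxygen, would match compound 3.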